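The source may hold more compounds than are shown below. What is called first, only, known or untested is meant among the compounds shown, and "the series" means these compounds.

Measured so far:
- compound 1, `COc1ccc(CN2CCc3nc(-c4ccccn4)nc(N4CCN(CCN(C)C)CC4)c3C2)cc1`: "not active" (no number reported)
- compound 2, `CN(C)CCN1CCN(c2nc(-c3ccccn3)nc3c2CN(Cc2ccc(F)cc2)CC3)CC1`: "not active" (no number reported)
- compound 3, `CC(C)c1ccc(CN2CCc3nc(-c4ccccn4)nc(N4CCN(CCN(C)C)CC4)c3C2)cc1`: 57.2%

Within the data shown here, in an assay on FRT cells with Cystic fibrosis transmembrane conductance regulator variant F508del (Homo sapiens) as the target, read by fluorescence, with a stated time of 25 min (on this read-out higher numbers stand for larger maximal responses and lower numbers for smaller maximal responses), compound 3 is the only member of the series for which a number has been obtained; compound 1 and compound 2 carry no figure, as both came back without activity. Within this small set compound 3 therefore stands alone, and nothing can be said about the size of any step among the three, since no pairwise step is available.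

Compound 4, `CN(C)CCN1CCN(c2nc(-c3ccccn3)nc3c2CN(C(=O)c2ccccc2)CC3)CC1`, is the next entry to be run in this assay. It departs from compound 3 by benzoyl in place of 4-isopropylbenzyl on an amine nitrogen in a ring. The two inactive entries, compound 1 and compound 2, both keep a benzyl-type group with a small substituent on that same amine nitrogen in a ring, while compound 3 carries the 4-isopropylbenzyl there; the benzoyl of compound 4 removes that group altogether and brings in an acyl group in its place.

Among the measured compounds shown here, with no step between measured compounds to lean on, the expectation for compound 4 rests on the pattern that only compound 3 produced a number. A step from compound 3 to compound 4 of a number 37.2 percentage points lower from compound 3 to compound 4 (beyond the scatter) is expected, downward and beyond the scatter, with a real chance of no activity at all. Compound 4 is estimated at 20%, within 0% to 50%.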

Compound 4, largest response reached (Emax), in percent of the reference or control that the assay uses: "not active" (no number reported)
Compound 4: no number reported; the estimate stays without a comparison.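

Among these compounds, compound 4 gives "not active" (no number reported) in this assay, so no step from compound 3 to compound 4 can be read. Nothing shown bears on the cause of this result. The compounds shown leave open how far the response of compound 3 depends on the 4-isopropylbenzyl itself, and whether any other group at that amine nitrogen gives a measurable response.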